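The source may report more compounds than this note shows. Statements on the series, on what has been measured and on what is new or still open speak of the compounds shown alone.

Measured so far:
compound 1 `CN(C)CCCNc1c(C(=O)NCc2ccc(F)cc2)nc(Br)c2cccnc12` — > 10000 nM
compound 2 `N[C@H]1CC[C@H](Nc2c(C(=O)NCc3ccccn3)nc(Br)c3cccnc23)CC1` — "not determined" (no result reported)

The study rests on two measured compounds that share a core. Compound 1 was tested in a functional assay on HCT-116 cells (Homo sapiens) for cytotoxicity, read by MTT assay, with a stated time of 72 h; on this read-out lower numbers stand for stronger inhibition and higher numbers for weaker inhibition. In this assay compound 1 gives > 10000 nM, which is a limit of the assay and not a number. For compound 2 the result in this assay is "not determined" (no result reported). So compound 1 stands at the limit of > 10000 nM in this assay, at which 1 of the 2 values shown sits, and no second number exists to place it against; no step between measured compounds can be read from these data.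

Compound 3 `O=C(NCc1ccc(F)cc1)c1nc(Br)c2cccnc2c1NCc1ccccc1` has not yet been measured in this assay. It differs from compound 1 in one place: phenyl in place of 2-(dimethylamino)ethyl on a saturated chain carbon bound to a nitrogen on an aromatic ring. Among the compounds with values here, since no measured step is available, the size of the change from compound 1 to compound 3 in this assay can only be guessed; the account expects no shift beyond the usual scatter, with compound 3 also likely to return only a limit. The step of a number no higher from compound 1 to compound 3 (the limit leaves the size open) is therefore expected to be essentially flat. Compound 3 is estimated at 10000 nM, with a range from 3000 nM to 30000 nM.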

Compound 3, half-maximal inhibitory concentration: > 20000 nM
Compound 3: no number, only a limit (the forecaster's own chance of this, stated with the estimate: 60%); middle value at least 2.0-fold (0.30 log units) from the limit.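

Compound 1 and compound 3 each return only a limit of the assay and not a number in this assay, so the step between them cannot be read. The compounds shown leave open what phenyl in place of 2-(dimethylamino)ethyl does to the value, and whether any compound on the shared core gives a single number in this assay.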